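Notes on the aryl group at the ring nitrogen

The source may report more compounds than this note shows. Statements on the series, on what has been measured and on what is new or still open speak of the compounds shown alone.

For the measured compounds named here, compound 3 `CC(C)(C)OC(=O)NCCCCCNC1=Nc2ccccc2C(CC(=O)NCc2ccccc2)N1c1ccccc1` gives 7740 nM in a functional assay on A549 cells (Homo sapiens) for inhibition, read by sulforhodamine B assay, with a stated time of 72 h (a higher number here means a weaker inhibitor of growth, a lower number a stronger inhibitor of growth), the higher of the two numbers known here. Compound 1 `CC(C)(C)OC(=O)NCCCCCN1C(Nc2ccc(-c3ccccc3)cc2)=Nc2ccccc2C1CC(=O)NCc1ccccc1` stands nearest with 1870 nM in this assay, a gap that lies beyond the scatter. Compound 2 `CN(C)C1=Nc2ccccc2C(CC(=O)NCc2ccc(N)cc2)N1c1ccccc1` returns only a limit in this assay, > 100000 nM, which marks (the limit of > 100000 nM in this assay, at which 1 of the 3 values shown sits).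

Compound 4 `CC(C)(C)OC(=O)NCCCCCNC1=Nc2ccccc2C(CC(=O)NCc2ccccc2)N1c1ccc(-c2ccccc2)cc1` differs from compound 3 by phenyl in place of hydrogen on an aromatic carbon. Going by the values given here, no measured pair differing in one place exists, so the size of this step is a guess. The expected step is a 2.2-fold lower number from compound 3 to compound 4 (0.34 log units; beyond the scatter), a modest gain in this assay, judged from compound 1, which also carries a 4-phenylphenyl group and gives 1870 nM. Compound 4 is estimated at 3500 nM in this assay, within 900 nM to 15000 nM.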

Compound 4, concentration for 50% growth inhibition: 1830 nM
Compound 4: middle estimate off by 1.9-fold (0.28 log units), on the high side; measured number inside the range.
By their numbers in this assay, from the lowest: compounds 4 and 1 (each within the scatter of the next); then compound 3. At a limit, above all of these: compound 2.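

In this assay, for the compounds shown here, the only pair differing in one place shows a 4.2-fold lower number from compound 3 to compound 4 (0.63 log units; beyond the scatter) for phenyl in place of hydrogen on an aromatic carbon, para to a large group. This position therefore accepts the added ring, with a gain in growth inhibition, although the finding rests on a single pair. No measurement at hand bears on the cause of this step.

Going by these compounds, whether a methyl, a chlorine, an amine or a carboxylic acid in the same place would give a step of like size stays open. So does whether the step holds with a shorter chain on the shared core.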